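Indole for isoquinoline on the longer-chain amide

A few compounds are considered here, and "the series" means these few. Any claim that something is new, unique, unknown or untested is made for them only; others in the source may bear on it.

Measured compounds:
compound 1 `CCCCCCCCCCCCNC(=O)[C@@H](NC(=O)c1nccc2ccccc12)[C@@H](C)O` — 62800 nM
compound 2 `CCCCCCCCCCCCNC(=O)[C@@H](NC(=O)c1cc2ccccc2[nH]1)[C@@H](C)O` — 10300 nM
compound 3 `CCCCCCCCCCCCCCNC(=O)[C@@H](NC(=O)c1nccc2ccccc12)[C@@H](C)O` — 23000 nM

All three values come from a functional assay on A-431 cells (Homo sapiens) for cytotoxicity, read by MTT assay, with a stated time of 48 h; on this read-out higher numbers stand for weaker inhibition and lower numbers for stronger inhibition. Two single changes branch from compound 1. The exchange of the aromatic group on the carbonyl, (1H-indol-2-yl in place of isoquinolin-1-yl on a carbonyl carbon), gives a 6.1-fold lower number from compound 1 to compound 2 (0.79 log units; beyond the scatter). The lengthening of the chain, (ethyl in place of hydrogen on a saturated chain carbon, ten or more bonds along the chain from an amide-type nitrogen), gives a 2.7-fold lower number from compound 1 to compound 3 (0.44 log units; beyond the scatter). Compound 2 and compound 3 are not joined by a single change; their values simply show compound 2 with the lower number.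

Compound 4 `CCCCCCCCCCCCCCNC(=O)[C@@H](NC(=O)c1cc2ccccc2[nH]1)[C@@H](C)O` has not been measured in this assay. It differs from compound 3 by 1H-indol-2-yl in place of isoquinolin-1-yl on a carbonyl carbon. This is the same change as from compound 1 to compound 2, and it occurs twice among these compounds; the place is described in the same words both times, so it is the same change, not merely the same kind. The two cores on which it is made differ by ethyl in place of hydrogen on a saturated chain carbon, ten or more bonds along the chain from an amide-type nitrogen.

The step is expected to be a 6.1-fold lower number from compound 3 to compound 4 (0.78 log units; beyond the scatter), set beside the measured 6.1-fold lower number from compound 1 to compound 2 (0.79 log units; beyond the scatter), on the assumption that the change carries over unchanged to the longer-chain core. Compound 4 is estimated at 3800 nM. For compound 4 the expected range runs from 1500 nM to 9500 nM, kept wide because only a 6.1-fold lower number from compound 1 to compound 2 (0.79 log units; beyond the scatter) supports the transfer.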

Compound 4, half-maximal inhibitory concentration: 12300 nM
Compound 4: middle estimate off by 3.2-fold (0.51 log units), on the low side; the whole stated range lies below it.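

In this assay, 1H-indol-2-yl in place of isoquinolin-1-yl on the longer-chain core gives a 1.9-fold lower number from compound 3 to compound 4 (0.27 log units; within the scatter), so the step measured on the shorter-chain core does not carry over in size to this core: the same change on two cores in this assay, a 6.1-fold lower number (0.79 log units; beyond the scatter) from compound 1 to compound 2 and a 1.9-fold lower number (0.27 log units; within the scatter) from compound 3 to compound 4, 3.3-fold (0.51 log units) apart, beyond the scatter of two such steps

Read along the other edge of the same four compounds, the chain lengthening gives a 1.2-fold higher number from compound 2 to compound 4 (0.08 log units; within the scatter), and it too fails to transfer from the isoquinolin-1-yl pair to the 1H-indol-2-yl pair: the same change on two cores in this assay, a 2.7-fold lower number (0.44 log units; beyond the scatter) from compound 1 to compound 3 and a 1.2-fold higher number (0.08 log units; within the scatter) from compound 2 to compound 4, 3.3-fold (0.51 log units) apart, beyond the scatter of two such steps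

The two changes therefore do not add up in this set, and the benefit of each is seen only when it is made on compound 1; this rests on one square of single values and shows neither the reason for the mismatch nor whether it would recur elsewhere in the series.

Still open is how the two changes behave together at other chain lengths, such as a decyl or a hexadecyl chain in place of the chains shown. Also open, from the compounds shown here alone, is whether another aromatic group on the carbonyl carbon, such as quinolin-2-yl or phenyl, would depend on chain length in the same way.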